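Sulfanyl side chain variation on the shared core

A few compounds are considered here, and "the series" means these few. Any claim that something is new, unique, unknown or untested is made for them only; others in the source may bear on it.

Among the measured compounds shown here, compound 1, `Cc1cc(N2CC[C@@H](C)[C@@H](N(C)c3ncnc4[nH]ccc34)C2)n2nc(SCCc3ccccc3)nc2n1`, is the single compound of the pair that returns a number rather than a limit in a functional assay on BGC-823 cells (Homo sapiens) for inhibition, read by MTT assay, with a stated time of 72 h; on this read-out higher numbers stand for weaker inhibition and lower numbers for stronger inhibition; there compound 1 gives 28000 nM. For the measured compounds named here, compound 2, `Cc1nc2nc(SCc3ccc(Cl)cc3)nn2c(N2CC[C@@H](C)[C@@H](N(C)c3ncnc4[nH]ccc34)C2)c1C`, differs from compound 1 in more than one place, so no single step joins the two. In this assay compound 2 reaches only > 100000 nM, which is a limit of the assay and not a number; this is the limit of > 100000 nM in this assay, at which 1 of the 2 values shown sits.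

Compound 3, `Cc1cc(N2CC[C@@H](C)[C@@H](N(C)c3ncnc4[nH]ccc34)C2)n2nc(SCc3ccc(F)cc3)nc2n1`, is not yet measured. Its change from compound 1 is 4-fluorophenyl in place of benzyl on a saturated chain carbon bound to a sulfur. Going by the values given here, no measured step of this kind is available on the shared core. Given that compound 2 with its (4-chlorobenzyl)sulfanyl chain sits at the limit of > 100000 nM in this assay, at which 1 of the 2 values shown sits, the expectation for compound 3 is a loss beyond the scatter in this assay, estimated as a 2.1-fold higher number from compound 1 to compound 3 (0.33 log units; beyond the scatter). Compound 3 is accordingly expected to give about 60000 nM in this assay, with a range from 20000 nM to 150000 nM, and a real chance that only a limit is reported.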

Compound 3, half-maximal inhibitory concentration: 44300 nM
Compound 3: middle estimate off by 1.4-fold (0.13 log units), on the high side; the measured number falls inside the stated range.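

In this assay, among the compounds shown here, going from phenethylsulfanyl to (4-fluorobenzyl)sulfanyl on the shared core gives the first step that can be read at this place: a 1.6-fold higher number from compound 1 to compound 3 (0.20 log units; within the scatter). This read-out therefore does not separate these two side chains, and a number rather than a limit is obtained with either of them on this core. Compound 2 remains a limit of the assay and not a number, and it differs from compound 1 in more than one place, so it supplies no step for this change: the limit of > 100000 nM in this assay, at which 1 of the 3 values shown sits.

The compounds shown do not separate the two places in which compound 2 differs from compound 1, so the part played by its (4-chlorobenzyl)sulfanyl chain remains unresolved, as does any separate contribution of the fluorine in compound 3. Also open, on these data alone, is how this assay would respond to an amine or a carboxylic acid at the end of the sulfanyl side chain, or to a plain methylsulfanyl group or a longer chain in its place.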